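Methyl on the piperidine of compound 1

A few compounds are considered here, and "the series" means these few. Any claim that something is new, unique, unknown or untested is made for them only; others in the source may bear on it.

Measured so far:
compound 1, `O=C(N1CCCCC1)N1CC(c2nc(-c3cccc(Cl)c3)no2)C1`, 370 nM
compound 2, `O=C(C1CCC(C(F)(F)F)CC1)N1CC(c2nc(-c3cccc(F)c3)no2)C1`, 680 nM

In an assay on HEK293 cells for positive allosteric modulation of metabotropic glutamate receptor 5 (Homo sapiens), read by FLIPR (on this read-out lower numbers stand for an effect already at smaller amounts and higher numbers for an effect only at larger amounts of compound), compound 1 gives 370 nM, the lower of the two numbers, while compound 2 gives 680 nM; the gap lies within the scatter, so no order between the two is claimed. Compound 3, `CC1CCN(C(=O)N2CC(c3nc(-c4cccc(Cl)c4)no3)C2)CC1`, is not yet measured. It differs from compound 1 by methyl in place of hydrogen on a saturated ring carbon, piperidin-1-yl to 4-methylpiperidin-1-yl. Within the data shown here, no measured pair here isolates such a change. The step of a 1.1-fold higher number from compound 1 to compound 3 (0.03 log units; within the scatter) is therefore expected to stay within the scatter. Compound 3 is estimated at 400 nM, range 150 nM to 1100 nM.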

Compound 3, half-maximal effective concentration: 865 nM
Estimate against measurement, compound 3: 2.2-fold (0.33 log units) below; measured number inside the range.
By their numbers in this assay, from the lowest: compounds 1, 2 and 3 (each within the scatter of the next, the first and the last beyond it).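

In this assay methyl in place of hydrogen on a saturated ring carbon, three ring bonds from the ring nitrogen, gives a 2.3-fold higher number from compound 1 to compound 3 (0.37 log units; beyond the scatter) as a modest step. Among these compounds, this is the first reading of a single change, and it shows that this ring carbon is not silent: one added carbon moves the number beyond the scatter. Nothing shown accounts for the step. Open, as far as these compounds go, is whether fluorine, hydroxyl or a longer chain such as ethyl at this carbon would move the number the same way.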